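Methyl next to the ring nitrogen in compound 1

The source may hold more compounds than are shown below. What is called first, only, known or untested is meant among the compounds shown, and "the series" means these compounds.

Potency here is read in an assay on OCI-Ly3 cells for activation of NF-kappa-B inhibitor alpha (Homo sapiens), read by a luciferase reporter; on this read-out lower numbers stand for an effect already at smaller amounts and higher numbers for an effect only at larger amounts of compound. Going by the values given here, compound 1 `COc1cc(NS(=O)(=O)c2ccc(C)cc2[N+](=O)[O-])c2ncccc2c1` gives 6800 nM in this assay, and that is the only number on hand, so compound 1 stands alone as the single measured point of the series. A second compound, compound 2 `COc1ccc(S(=O)(=O)Nc2cccc3ccc(C)nc23)c([N+](=O)[O-])c1`, shares the sulfonamide and the methoxy group but carries its methyl on the core; for compound 2 this assay reports "not determined" (no result reported), so it adds no number. Among the compounds with values here, no step between two measured compounds exists, and nothing shows yet how a change on the core of compound 1 moves the read-out.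

Compound 3 `COc1cc(NS(=O)(=O)c2ccc(C)cc2[N+](=O)[O-])c2nc(C)ccc2c1` differs from compound 1 by methyl in place of hydrogen on an aromatic carbon. Within the data shown here, with no measured step to draw on, the expected change in this assay is small, not beyond the usual scatter, and without a clear direction. The estimate for compound 3 in this assay is 5500 nM. The range expected for compound 3 runs from 1800 nM to 17000 nM. The step this estimate means, a 1.2-fold lower number from compound 1 to compound 3 (0.09 log units; within the scatter), is expected to stay inside the scatter.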

Compound 3, half-maximal effective concentration: > 10000 nM
Compound 3: only a limit was reported (the forecaster's own chance of this, stated with the estimate: 15%); at least 1.8-fold (0.25 log units) between middle value and limit.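

Methyl in place of hydrogen on an aromatic carbon, next to the ring nitrogen, gives the series its first step on the core of compound 1, namely an at least 1.4-fold higher number from compound 1 to compound 3 (0.16 log units; that floor lies within the scatter). In this assay compound 3 is reported only as a limit, > 10000 nM, so the step has a floor and no fixed size. That floor alone does not separate compound 3 from compound 1, yet nothing here shows methyl at this position lowering the number, and the reading for this position ends at the edge of what the assay reports: the limit of > 10000 nM in this assay, at which 1 of the 3 values shown sits.

How far compound 3 really lies from compound 1 stays open, and so does any reason for the step, since the compounds shown give no measured property of this methyl. Also open, going by these compounds, is how the read-out answers to a different group on this same aromatic carbon, such as an amine, a chlorine atom or a longer chain like ethyl.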